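This account rests on a few compounds, and the source may have more. Where it says the series, first, only, none or still open, it means among the compounds named here.

Compounds 1, 2 and 3 share one core, seen in compound 1 `Cc1c(Oc2ccccc2OCCn2ccc(=O)[nH]c2=O)cc(F)c2ccc(C#N)cc12`, compound 2 `Cc1c(Oc2ccc(F)cc2OCCn2ccc(=O)[nH]c2=O)cc(F)c2ccc(C#N)cc12` and compound 3 `Cc1c(Oc2ccc(F)cc2OCCn2ccc(=O)[nH]c2=O)cc(Cl)c2ccc(C#N)cc12`. In a toxicity assay on MT2 cells (Homo sapiens) for cytotoxicity, read by MTT assay (on this read-out higher numbers stand for lower toxicity in this test and lower numbers for higher toxicity in this test), compound 1 gives only a limit of the assay, > 100000 nM. Compound 2 also gives only a limit in this assay, > 100000 nM. Compound 3 gives a number in this assay, 82000 nM. Compound 2 thus stands at the limit, and the limit of > 100000 nM in this assay, at which 2 of the 3 values shown sit, shows that compound 1 sits there with it, so only compound 3 carries a readable number. The step that the two limits leave unreadable from compound 1 to compound 2 cannot be read from these two limits. Within the data shown here, the step of an at least 1.2-fold lower number from compound 2 to compound 3 (0.08 log units; that floor lies within the scatter) is the only measured exchange of one halogen for another, and its floor lies within the scatter. Compound 4 `Cc1c(Oc2ccc(Cl)cc2OCCn2ccc(=O)[nH]c2=O)cc(F)c2ccc(C#N)cc12` differs from compound 2 by chloro in place of fluoro on an aromatic carbon. Among the measured compounds shown here, this is the same kind of exchange as in an at least 1.2-fold lower number from compound 2 to compound 3 (0.08 log units; that floor lies within the scatter), which is the one step that bears on it; it gives no ground to expect a shift beyond the scatter. For compound 4 the expected step is therefore an at least 1.1-fold lower number from compound 2 to compound 4 (0.07 log units; that floor lies within the scatter). The estimate for compound 4 in this assay is 85000 nM, with a range from 40000 nM to 200000 nM, and a limit rather than a number remains quite possible.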

Compound 4, half-maximal cytotoxic concentration: 6000 nM
Estimate against measurement, compound 4: 14-fold (1.15 log units) above; the measured number lies below the stated range.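

In this assay, among these compounds, chloro in place of fluoro on this carbon, meta to a large group and para to a large group, gives an at least 16-fold lower number from compound 2 to compound 4 (1.22 log units; beyond the scatter), which means higher toxicity in this test; the same kind of exchange elsewhere on the shared core had given an at least 1.2-fold lower number from compound 2 to compound 3 (0.08 log units; that floor lies within the scatter), so this is the first such exchange with a floor beyond the scatter. Chloro in place of hydrogen on the same carbon gives an at least 16-fold lower number from compound 1 to compound 4 (1.22 log units; beyond the scatter), so among these three compounds only the one with chloro here carries a readable number. Both sizes remain floors rather than full measures, because compound 1 and compound 2 stand at a limit: the limit of > 100000 nM in this assay, at which 2 of the 4 values shown sit.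

The compounds shown leave open whether bromo, methyl or methoxy on this carbon would also lower the number, or whether the step belongs to chloro alone. They also leave open whether chloro on both of the halogen-bearing carbons would lower the number further than chloro on this carbon alone.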